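Aryl Swap on the Benzylic Sulfur of Compound 3

The compounds below may be only part of what the source reports. "The series", "measured", "known", "first", "only" and "open" are said of these compounds alone.

Compound 3 `Cc1cc(S(=O)(=O)/N=C(\N)n2nccc2-c2ccccc2)c(SCc2cccc3ccccc23)cc1Cl` gives 7000 nM in a functional assay on HCT-116 cells (Homo sapiens) for cytotoxicity, read by MTT assay, with a stated time of 72 h; on this read-out lower numbers stand for stronger inhibition and higher numbers for weaker inhibition. On that read-out compound 3 stands level with compound 1 `Cc1cc(S(=O)(=O)/N=C(\N)n2nccc2-c2ccccc2)c(SCc2cccc(Cl)c2)cc1Cl`, which gives 7000 nM, the two together the lowest of three numbers, while compound 2 `Cc1cc(S(=O)(=O)/N=C(\N)n2nccc2-c2ccccc2)c(SCc2ccc(C(F)(F)F)cc2)cc1Cl` gives 14000 nM. Compound 4 `Cc1ccc(CSc2cc(Cl)c(C)cc2S(=O)(=O)/N=C(\N)n2nccc2-c2ccccc2)cc1` differs from compound 3 by 4-methylphenyl in place of naphthalen-1-yl on a saturated chain carbon bound to a sulfur. The measured steps that bear on this all concern changes at the same place: no change at the digits printed from compound 1 to compound 3 (within the scatter), a 2.0-fold lower number from compound 2 to compound 3 (0.30 log units; within the scatter) and a 2.0-fold higher number from compound 1 to compound 2 (0.30 log units; within the scatter), none of them beyond the scatter. Three different aryl groups at that carbon gave numbers within the scatter of one another, so compound 4 is expected to show no step beyond the scatter, a 1.3-fold higher number from compound 3 to compound 4 (0.11 log units; within the scatter). Compound 4 is accordingly estimated at 9000 nM, with a range from 3500 nM to 25000 nM.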

Compound 4, half-maximal inhibitory concentration: 14000 nM
Compound 4: middle estimate off by 1.6-fold (0.19 log units), on the low side; the range from low to high includes it.
By their numbers in this assay, from the lowest: compounds 1, 3, 2 and 4 (each within the scatter of the next).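

Going from two six-membered aromatic rings to one at the saturated chain carbon bound to a sulfur stays inside the noise in this assay, with a 2.0-fold higher number from compound 3 to compound 4 (0.30 log units; within the scatter). Methyl in place of trifluoromethyl on an aromatic carbon leaves the reading unmoved, with no change at the digits printed from compound 2 to compound 4 (within the scatter), and the swap for 3-chlorophenyl gives a 2.0-fold higher number from compound 1 to compound 4 (0.30 log units; within the scatter). All four aryl groups at this carbon therefore remain within the scatter of their neighbours in the ranking. No measurement shown offers an explanation for this. From the compounds shown here alone, whether an aryl group carrying an amine or a carboxylic acid, or a longer chain on the sulfur, would give a step beyond the scatter stays open.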